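Series notes: distal aryl swap on compound 2

The source may report more compounds than this note shows. Statements on the series, on what has been measured and on what is new or still open speak of the compounds shown alone.

Compound 2 `COc1cccc(CNCCCNc2ccnc3cc(-c4ccc(F)cc4)ccc23)c1O` gives 9.47 in a physicochemical assay for acid dissociation. Compound 1 `Fc1ccc(-c2ccc3c(NCCCNCc4ccco4)ccnc3c2)cc1` gives 9.47 in this assay, and compound 3 `COc1ccc(F)cc1CNCCCNc1ccnc2cc(-c3ccc(F)cc3)ccc12` gives 9.47 in this assay, so compound 2 stands level with both at the digits shown. All three measured steps exchange the group on the saturated chain carbon bound to an amine nitrogen: no change at the digits printed from compound 1 to compound 2 (within the scatter), no change at the digits printed from compound 1 to compound 3 (within the scatter) and no change at the digits printed from compound 2 to compound 3 (within the scatter). Compound 4 `COc1ccc(Oc2ccc3c(NCCCNCc4cccc(OC)c4O)ccnc3c2)cc1` is not yet measured. It differs from compound 2 by 4-methoxyphenoxy in place of 4-fluorophenyl on an aromatic carbon. Among the compounds with values here, none of the measured steps touches that aromatic carbon of the fused ring system; they show only that the value did not move when the group on the chain carbon was varied. Within the data shown here, no measured step bears directly on the new change, so the expectation rests on the flatness of the series. Compound 4 is therefore expected to show no change at the digits printed from compound 2 to compound 4 (within the scatter), no step beyond the scatter. The estimate for compound 4 is 9.47, with a range from 9.1 to 9.8.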

Compound 4, acid dissociation constant: 9.28
Estimate against measurement, compound 4: 0.19 log units above; the range from low to high includes it.
By their numbers in this assay, from the lowest: compounds 4, 1, 2 and 3 (each within the scatter of the next).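

In this assay, the first change shown at this aromatic carbon of the shared core gives a number 0.19 log units lower from compound 2 to compound 4 (within the scatter). The earlier steps shown here varied only the group on the chain carbon, whereas this one shows that replacing 4-fluorophenyl with 4-methoxyphenoxy, which takes the count from 7 to 9 heavy atoms and from 0 to 2 hydrogen-bond acceptors, also leaves the value within the scatter. No evidence is available here on what underlies this reading.

Only one exchange is shown at this carbon, so it remains open whether an amine or a carboxylic acid there would also stay within the scatter in this assay. Within the data shown here, this exchange is also seen only with 2-hydroxy-3-methoxyphenyl on the chain carbon, so its size with furan-2-yl or 5-fluoro-2-methoxyphenyl there remains open.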